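Methyl on the shared core, compound 3 to compound 4

This account rests on a few compounds, and the source may have more. Where it says the series, first, only, none or still open, it means among the compounds named here.

Measured so far in an ADME assay on HEK-293T cells (Homo sapiens) for cytotoxicity, read by luminescence, with a stated time of 24 h; a higher number here means that more compound is tolerated, a lower number that less compound is tolerated
compound 1 `CCOC(=O)C1CCN(C(=O)c2cc3sccc3n2Cc2ccc(OC)cc2)CC1` gives 39000 nM
compound 2 `COc1ccc(Cn2c(C(=O)N3CCC(C(=O)NCc4cccc(Br)c4)CC3)cc3sccc32)cc1` gives > 100000 nM (a limit of the assay, not a number)
compound 3 `CCCNC(=O)C1CCN(C(=O)c2cc3sccc3n2Cc2ccc(OC)cc2)CC1` gives 18800 nM

Compound 3 holds the lowest of the two true numbers in this assay and compound 1 is its nearest neighbour. The step between them is a 2.1-fold lower number from compound 1 to compound 3 (0.32 log units; beyond the scatter) with propylamino in place of ethoxy on a carbonyl carbon. Both an at least 2.5-fold higher number from compound 1 to compound 2 (0.40 log units; beyond the scatter) and an at least 5.3-fold lower number from compound 2 to compound 3 (0.72 log units; beyond the scatter) rest on the limit of compound 2 and give only a bound.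

Compound 4 `CCCNC(=O)C1CCN(C(=O)c2cc3sc(C)cc3n2Cc2ccc(OC)cc2)CC1` carries methyl in place of hydrogen on an aromatic carbon, next to the ring sulfur methyl in place of hydrogen on an aromatic carbon and is otherwise the same as compound 3. Going by the values given here, no measured step touches that carbon, since all three alter the amide end of the series. These steps therefore bear on the change only indirectly, as a guide to how far values move in this assay in this small set. With so little to go on, no step beyond the scatter is expected, perhaps a slight fall in the number. The expected step is a 1.2-fold lower number from compound 3 to compound 4 (0.07 log units; within the scatter) and it remains an estimate. Compound 4 is estimated at 16000 nM (expected range 6500 nM to 40000 nM).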

Compound 4, half-maximal cytotoxic concentration: 36300 nM
Compound 4: middle estimate off by 2.3-fold (0.36 log units), on the low side, within the range that was stated.
By their numbers in this assay, from the lowest: compounds 3, 4 and 1 (each within the scatter of the next, the first and the last beyond it). At a limit, above all of these: compound 2.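

In this assay, going by these compounds alone, this is the first reading at an aromatic carbon of the five-membered aromatic ring with 1 sulfur, next to the ring sulfur, and methyl in place of hydrogen there gives a 1.9-fold higher number from compound 3 to compound 4 (0.29 log units; within the scatter). The earlier step at the amide end, a 2.1-fold lower number from compound 1 to compound 3 (0.32 log units; beyond the scatter), lies beyond the scatter, whereas this one on the shared core does not, so for this single pair the carbon accepts methyl without a step beyond the scatter. Nothing measured here speaks to what lies behind this step.

One pair cannot show whether this carbon stays as undemanding with other groups, and a chlorine atom, a longer chain such as butyl, or a carboxylic acid at the same place could each behave differently from methyl. As far as these compounds go, it also remains open whether methyl at this carbon gives a step of the same size when the amide end is the ethyl ester of compound 1 or the (3-bromobenzyl)amino group of compound 2.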